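Fluoro step from compound 1 to compound 3

A few compounds are considered here, and "the series" means these few. Any claim that something is new, unique, unknown or untested is made for them only; others in the source may bear on it.

In an ADME assay on HEK293 cells (Homo sapiens) for cytotoxicity, with a stated time of 72 h (on this read-out lower numbers stand for an effect already at smaller amounts and higher numbers for an effect only at larger amounts of compound), compound 1 `Cc1cc(NC(=O)Nc2cccc(F)c2)c2ccccc2n1` gives > 25000 nM as a limit of the assay, not a number. Compound 2 `COc1ccc(NC(=O)Nc2cc(C)nc3ccccc23)cc1F` gives > 25000 nM, again a limit and not a number. Both compounds therefore share the same position: the limit of > 25000 nM in this assay, at which 2 of the 2 values shown sit. No numerical value is yet available in this series.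

Compound 3 `Cc1cc(NC(=O)Nc2cc(F)cc(F)c2)c2ccccc2n1` keeps the core of compound 1 and differs from it by fluoro in place of hydrogen on an aromatic carbon, with the new fluoro meta to a fluoro group.

For the measured compounds named here, the only measured step bearing on this change is a step that the two limits leave unreadable from compound 1 to compound 2 for methoxy in place of hydrogen on an aromatic carbon. It gives no size to carry over, but it shows compound 2 remaining at the same limit as compound 1. On that basis, no change beyond the usual scatter is expected. For compound 3 the estimated step is a step that the limit leaves unreadable from compound 1 to compound 3 in this assay, and a report as a limit is the likeliest outcome. For compound 3 the estimated value is 30000 nM, with an expected range from 15000 nM to 50000 nM, pending measurement.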

Compound 3, half-maximal effective concentration: > 25000 nM
Compound 3 was reported as a limit; the forecaster's own chance of this, stated with the estimate: 85%; the middle value is on the limit's open side.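

The step from compound 1 to compound 3 cannot be read, and neither can the one from compound 1 to compound 2, since compound 1, compound 2 and compound 3 all stand at the same limit of the assay: the limit of > 25000 nM in this assay, at which 3 of the 3 values shown sit.

The compounds shown leave open whether fluoro or methoxy in place of hydrogen shifts the read-out in this assay at all, as the series still holds no numerical value.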